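The compounds below may be only part of what the source reports. "The series", "measured", "known", "first", "only" and "open" are said of these compounds alone.

Compound 1 `O=C(NCc1ccc(S(=O)(=O)c2ccccc2)cc1)N1Cc2ccncc2C1` gives 7.5 mL/min/kg in an ADME assay on microsomes from liver (Homo sapiens) for pharmacokinetics, read by LC-MS, with a stated time of 60 min, tested at 1 uM; a higher number here means faster removal of the compound, a lower number slower removal.
Compound 2 `O=C(NCc1ccc(S(=O)(=O)c2cc(F)cc(F)c2)cc1)N1Cc2ccncc2C1` gives 8 mL/min/kg.
Compound 3 `CCC(=O)N1CCC(S(=O)(=O)c2ccc(CNC(=O)N3Cc4ccncc4C3)cc2)CC1` gives 11 mL/min/kg.

Among these three, compound 2 stands second highest in this assay: its nearest neighbour is compound 1, with a 1.1-fold higher number from compound 1 to compound 2 (0.03 log units; within the scatter), and its furthest is compound 3, with a 1.4-fold higher number from compound 2 to compound 3 (0.14 log units; within the scatter), both within the scatter. Compound 4 `O=C(NCc1ccc(S(=O)(=O)N2CC3(CCOCC3)C2)cc1)N1Cc2ccncc2C1` changes the group on the sulfonyl sulfur: a group of 9 heavy atoms (7 carbon, 1 nitrogen, 1 oxygen; one four-membered non-aromatic ring with 1 hetero atom, one six-membered non-aromatic ring with 1 hetero atom) in place of a group of 8 heavy atoms (6 carbon, 2 fluorine; one six-membered aromatic ring of carbon only), on a sulfonyl sulfur. Within the data shown here, the steps that bear on this are the earlier swaps at the same sulfonyl sulfur, a 1.1-fold higher number from compound 1 to compound 2 (0.03 log units; within the scatter) and a 1.5-fold higher number from compound 1 to compound 3 (0.17 log units; within the scatter), each within the scatter. Among the measured compounds shown here, no measured step introduces a group with a four-membered ring, so the expectation rests on those small moves. For compound 4 the expected step is a 1.1-fold higher number from compound 2 to compound 4 (0.05 log units; within the scatter), with no change beyond the scatter. Compound 4 is estimated at 9 mL/min/kg, ranging from 5 mL/min/kg to 16 mL/min/kg.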

Compound 4, clearance: 13 mL/min/kg
The estimate for compound 4 lay 1.4-fold (0.16 log units) below the measured number; the measured number falls inside the stated range.
By their numbers in this assay, from the lowest: compounds 1, 2, 3 and 4 (each within the scatter of the next).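

In this assay the new group on the sulfonyl sulfur, with its four-membered and six-membered rings, stays within the scatter of all three earlier compounds (a 1.6-fold higher number from compound 2 to compound 4 (0.21 log units; within the scatter); a 1.2-fold higher number from compound 3 to compound 4 (0.07 log units; within the scatter); a 1.7-fold higher number from compound 1 to compound 4 (0.24 log units; within the scatter)). Among these compounds, all four groups at this position, aromatic or not, therefore give numbers that no step separates beyond the scatter. Nothing available here explains these numbers.

Still open, from the compounds shown here alone, is whether a group carrying an amine or a carboxylic acid on the sulfonyl sulfur would move the number beyond the scatter. A small open chain such as ethyl leaves the same question.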